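The compounds below may be only part of what the source reports. "The series", "measured", "known", "first", "only" and "open" are said of these compounds alone.

Compound 1 `N#Cc1c(NN)nc(SCc2nc3ccccc3[nH]2)nc1-c1ccccc1`: 2.7 nM
Compound 2 `N#Cc1c(NNC(N)=S)nc(SCc2nc3ccccc3[nH]2)nc1-c1ccccc1`: 3 nM
Compound 3 `N#Cc1c(NC(N)=O)nc(SCc2nc3ccccc3[nH]2)nc1-c1ccccc1`: 6.75 nM

All three values come from a functional assay on SK-OV-3 cells (Homo sapiens) for cytotoxicity, read by MTT assay, with a stated time of 3 days; a lower number here means a stronger inhibitor, a higher number a weaker inhibitor. Among them, compound 3 has the highest number, 6.75 nM, and so it is the weakest inhibitor of the three.

The next compound to be tested is compound 4 `N#Cc1c(-c2ccccc2)nc(SCc2nc3ccccc3[nH]2)nc1N1CCNCC1`. It keeps the shared core of compound 3 and changes one group: piperazin-1-yl in place of ureido on an aromatic carbon. In short, piperazin-1-yl stands in place of ureido on an aromatic carbon.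

The measured steps that bear on this change involve the groups on that same carbon. They are all small: a 1.1-fold higher number from compound 1 to compound 2 (0.05 log units; within the scatter), a 2.5-fold higher number from compound 1 to compound 3 (0.40 log units; beyond the scatter) and a 2.3-fold higher number from compound 2 to compound 3 (0.35 log units; beyond the scatter). None of those groups has a ring, and the data hold no measurement of piperazin-1-yl, so this guidance is indirect and the range must stay wide.

With steps of that size, no change beyond the scatter is expected in this assay. The expected change is a 1.4-fold lower number from compound 3 to compound 4 (0.13 log units; within the scatter). For compound 4 the estimated value is 5 nM, with an expected range from 1.5 nM to 20 nM.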

Compound 4, half-maximal inhibitory concentration: 2.63 nM
The estimate for compound 4 lay 1.9-fold (0.28 log units) above the measured number; measured number inside the range.
By their numbers in this assay, from the lowest: compounds 4, 1 and 2 (each within the scatter of the next); then compound 3.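

In this assay, the position on the aromatic carbon next to the ring nitrogen, ortho to the cyano group, also accepts a group with a ring: piperazin-1-yl, the only ring-bearing group at this position among these compounds, gives a 2.6-fold lower number from compound 3 to compound 4 (0.41 log units; beyond the scatter). That step shows that replacing ureido with this larger ring does not weaken the compound, and compound 3 now stands as the weakest of the four, with all three of its steps beyond the scatter. The other two comparisons, a 1.1-fold lower number from compound 2 to compound 4 (0.06 log units; within the scatter) and a 1.0-fold lower number from compound 1 to compound 4 (0.01 log units; within the scatter), stay within the scatter, so the ring performs on a par with the two open-chain groups of compound 1 and compound 2, and no measurement is available to explain any of these results.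

The compounds shown leave open whether the second ring nitrogen of piperazin-1-yl matters, which a morpholin-4-yl group, with oxygen at that ring position, or a piperidin-1-yl group, with carbon there, could test. They also leave open whether a substituent on that nitrogen, such as a methyl group or a longer chain, would be accepted as readily as the unsubstituted ring.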